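Carbamate tail variation in the growth hormone secretagogue series

This account rests on a few compounds, and the source may have more. Where it says the series, first, only, none or still open, it means among the compounds named here.

Measured so far in a functional assay on H4 cells with growth hormone secretagogue receptor type 1 (Homo sapiens) as the target, read by FLIPR; on this read-out higher numbers stand for an effect only at larger amounts of compound and lower numbers for an effect already at smaller amounts:
compound 1 `CC(C)(N)C(=O)N[C@H](COCc1ccccc1)c1nnnn1CCOC(=O)NCCO`, 3 nM
compound 2 `CC1(O)CCN(C(=O)OCCn2nnnc2[C@@H](COCc2ccccc2)NC(=O)C(C)(C)N)C1`, 10.1 nM
compound 3 `CC(=O)NCCCCNC(=O)OCCn1nnnc1[C@@H](COCc1ccccc1)NC(=O)C(C)(C)N`, 82.5 nM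

Compound 3 stands highest of the three numbers in this assay; its nearest neighbour is compound 2, with an 8.2-fold higher number from compound 2 to compound 3 (0.91 log units; beyond the scatter), and compound 1 lies furthest, with a 28-fold higher number from compound 1 to compound 3 (1.44 log units; beyond the scatter). Compound 4 `CC(=O)N[C@@H]1CCN(C(=O)OCCn2nnnc2[C@@H](COCc2ccccc2)NC(=O)C(C)(C)N)C1` carries the change (3-acetamidopyrrolidin-1-yl in place of (4-acetamidobutyl)amino on a carbonyl carbon). The step of an 8.2-fold higher number from compound 2 to compound 3 (0.91 log units; beyond the scatter) bears most directly on it, as it exchanged a pyrrolidinyl ring for an open acetamidobutyl chain and raised the number; the step of a 3.4-fold higher number from compound 1 to compound 2 (0.53 log units; beyond the scatter) shows a pyrrolidinyl ring is tolerated. Returning to a pyrrolidine while keeping the acetamido group is therefore expected to lower the number, by about a 4.1-fold lower number from compound 3 to compound 4 (0.62 log units; beyond the scatter). Compound 4 is estimated at 20 nM, with a range of 5 nM to 60 nM.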

Compound 4, half-maximal effective concentration: 3.3 nM
The estimate for compound 4 lay 6.1-fold (0.78 log units) above the measured number; the measured number lies below the stated range.
By their numbers in this assay, from the lowest: compounds 1 and 4 (each within the scatter of the next); then compound 2; then compound 3.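

In this assay, on this carbonyl carbon the 3-acetamidopyrrolidin-1-yl group separates sharply from the open (4-acetamidobutyl)amino chain of the same heavy-atom count (a 25-fold lower number from compound 3 to compound 4 (1.40 log units; beyond the scatter)), so the acetamido group itself does not carry the high number of compound 3. The pyrrolidine substituent also counts (a 3.1-fold lower number from compound 2 to compound 4 (0.49 log units; beyond the scatter)), whereas the change from (2-hydroxyethyl)amino stays within the scatter (a 1.1-fold higher number from compound 1 to compound 4 (0.04 log units; within the scatter)). Nothing at hand explains these differences.

Open, as far as these compounds go, is whether ring closure or chain length drives the first step, which (2-acetamidoethyl)amino would test. Also open, from the compounds shown here alone, is how a 3-aminopyrrolidin-1-yl group would compare.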